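Bromo Enters the Fused Ring of a Weak Antiproliferative

The source may report more compounds than this note shows. Statements on the series, on what has been measured and on what is new or still open speak of the compounds shown alone.

Of the compounds shown here, two have been measured so far. Compound 1 `O=C1Nc2c(F)cccc2/C1=C1/Nc2ccccc2C1=O` gives 16300 nM in a functional assay on B16-F10 cells (Mus musculus) for antiproliferative activity, read by MTT assay, with a stated time of 72 h; a lower number here means a stronger inhibitor, a higher number a weaker inhibitor. Compound 2 `O=C1NC(=S)N/C1=C1\C(=O)Nc2ccccc21` gives 41600 nM in this assay, the highest of the two numbers; its nearest neighbour is compound 1, whose number is lower by a gap beyond the usual scatter, so compound 2 is the weaker inhibitor of the pair.

Compound 3 `O=C1NC(=S)N/C1=C1\C(=O)Nc2c(Br)cccc21` is not yet measured in this assay. It differs from compound 2 in one place: bromo in place of hydrogen on an aromatic carbon. Within the data shown here, no pair of measured compounds shares this change, so nothing measured here tells how such a replacement shifts the number, and the expectation rests on compound 2 alone. The expected step, a 1.7-fold lower number from compound 2 to compound 3 (0.22 log units; within the scatter), is a modest move toward a lower number, not far outside the scatter. Compound 3 is accordingly expected to give 25000 nM in this assay, within a range from 8000 nM to 70000 nM.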

Compound 3, half-maximal inhibitory concentration: 5000 nM
Compound 3: middle estimate off by 5.0-fold (0.70 log units), on the high side; the measured number lies below the stated range.
By their numbers in this assay, from the lowest: compound 3; then compound 1; then compound 2.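

In this assay, bromo in place of hydrogen on an aromatic carbon gives an 8.3-fold lower number from compound 2 to compound 3 (0.92 log units; beyond the scatter), a step beyond the usual scatter. Among these compounds, this is the first measured sign that the number responds to a change at this place on the six-membered aromatic ring, ortho to a fused ring and meta to a fused ring; the earlier compounds offered no pair showing the direction or size of such a shift. No available evidence bears on the reason for this step.

The compounds shown leave open whether the shift is particular to bromo or would also follow from another group on this carbon, such as chloro, methyl or an amine. They also leave open whether bromo on another carbon of this ring would move the number in the same direction.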